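The source may hold more compounds than are shown below. What is called first, only, known or untested is meant among the compounds shown, and "the series" means these compounds.

Measured compounds:
compound 1, `COc1ccc(-c2cc3ccccc3nc2/C=C/C(=O)c2ccc(O)cc2)cc1`, 6350 nM 
compound 2, `COc1ccc(-c2cc3ccccc3nc2/C=C/C(=O)c2ccc(OC)cc2OC)cc1`, 3210 nM 

In a functional assay on MDA-MB-231 cells (Homo sapiens) for antiproliferative activity, read by XTT assay, with a stated time of 72 h (a lower number here means a stronger inhibitor, a higher number a weaker inhibitor), compound 1 gives 6350 nM, and compound 2 gives 3210 nM. For the measured compounds named here, the one step between them, a 2.0-fold lower number from compound 1 to compound 2 (0.30 log units; within the scatter), replaces a 4-hydroxyphenyl with a 2,4-dimethoxyphenyl on the carbonyl carbon; it stays within the scatter, so the two numbers cannot be told apart with confidence. Going by the values given here, compound 2 has the lowest of the two numbers, with compound 1 its only neighbour.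

Compound 3, `COc1ccc(-c2cc3ccccc3nc2/C=C/C(=O)c2c(OC)cccc2OC)cc1`, keeps every atom of compound 2 and differs only in the arrangement: 2,6-dimethoxyphenyl in place of 2,4-dimethoxyphenyl on a carbonyl carbon. Among the compounds with values here, no measured step moves a methoxy group from one place to another on this ring; the only step that touches this ring at all, a 2.0-fold lower number from compound 1 to compound 2 (0.30 log units; within the scatter), was within the scatter. On that basis compound 3 is expected to sit close to compound 2, with a 1.2-fold higher number from compound 2 to compound 3 (0.10 log units; within the scatter), a step that would itself lie within the scatter. The estimate for compound 3 in this assay is therefore 4000 nM, with a range from 1500 nM to 11000 nM.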

Compound 3, half-maximal inhibitory concentration: 5630 nM
Beside the measured number, compound 3's estimate is 1.4-fold (0.15 log units) below it; the measured number falls inside the stated range.
By their numbers in this assay, from the lowest: compounds 2, 3 and 1 (each within the scatter of the next).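

In this assay, for the compounds shown here, this is the first reading of a pure change of arrangement on the ring at the carbonyl carbon: going from 2,4-dimethoxyphenyl to 2,6-dimethoxyphenyl gives a 1.8-fold higher number from compound 2 to compound 3 (0.24 log units; within the scatter) and leaves the atoms the same. Replacing 4-hydroxyphenyl with 2,6-dimethoxyphenyl gives a 1.1-fold lower number from compound 1 to compound 3 (0.05 log units; within the scatter), so neither arrangement of the two methoxy groups can be told apart from 4-hydroxyphenyl, and all three groups tried at this place remain indistinguishable in this assay. Nothing at hand offers an explanation for these numbers.

The compounds shown leave open whether any group on this carbonyl carbon can shift the number beyond the scatter, as all three rings here carry only hydroxyl or methoxy groups, and an amine, a carboxylic acid or a fluorine on the ring would test a different kind of substituent. They also leave open whether changes elsewhere on the shared core, or in the double-bonded chain that joins it to the carbonyl carbon, would have a readable effect in this assay.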